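A few compounds are considered here, and "the series" means these few. Any claim that something is new, unique, unknown or untested is made for them only; others in the source may bear on it.

Measured so far in a physicochemical assay for lipophilicity, using the shake flask method, at pH 7.4; a lower number here means a more polar compound, a higher number a more lipophilic compound:
compound 1 `O=C(O)C[C@H](O)C[C@H](O)CCn1c(-c2ccc(F)cc2)nc(C(=O)NCc2ccccc2F)c1C1CC1` gives 0.08
compound 2 `Cc1ccc(CNC(=O)c2nc(-c3ccc(F)cc3)n(CC[C@@H](O)C[C@@H](O)CC(=O)O)c2C2CC2)cc1` gives 0.45
compound 3 `COc1ccccc1CNC(=O)c1nc(-c2ccc(F)cc2)n(CC[C@@H](O)C[C@@H](O)CC(=O)O)c1C1CC1` gives 0.16

Compound 1 sits at the polar end of this small set. Compound 2 lies away from it by a number 0.37 log units higher from compound 1 to compound 2 (beyond the scatter), a modest step that comes with 4-methylphenyl in place of 2-fluorophenyl on a saturated chain carbon bound to an amide-type nitrogen. Compound 3, with methoxy in place of fluoro on an aromatic carbon, differs from compound 1 by only a number 0.08 log units higher from compound 1 to compound 3 (within the scatter), and the gap between compound 2 and compound 3 is a number 0.29 log units lower from compound 2 to compound 3 (within the scatter), again inside the usual scatter.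

Compound 4 `O=C(O)C[C@H](O)C[C@H](O)CCn1c(-c2ccc(F)cc2)nc(C(=O)NCc2ccccc2)c1C1CC1` is the unmeasured member. It differs from compound 1 as follows: hydrogen in place of fluoro on an aromatic carbon

Among the compounds with values here, no measured step removes a substituent outright; the closest analogy is the swap of fluoro for methoxy that took compound 1 to compound 3, which stayed within the scatter. The larger step to compound 2 involved a different ring and a different position, so it bears only loosely. The expectation for compound 4 in this assay is therefore a step of about a number 0.13 log units lower from compound 1 to compound 4 (within the scatter), not beyond the scatter, leaning slightly lower. Compound 4 is estimated at -0.05, within -0.35 to 0.25.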

Compound 4, distribution coefficient: 0.03
The estimate for compound 4 lay 0.08 log units below the measured number; the range from low to high includes it.
By their numbers in this assay, from the lowest: compounds 4, 1, 3 and 2 (each within the scatter of the next, the first and the last beyond it).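

In this assay, the fluoro on the aromatic carbon ortho to a large group can be replaced by hydrogen with a step of a number 0.05 log units lower from compound 1 to compound 4 (within the scatter), so this read-out does not separate 2-fluorobenzyl from benzyl. Adding a number 0.13 log units lower from compound 3 to compound 4 (within the scatter) shows that hydrogen, fluoro and methoxy at this place all lie within the scatter of one another, where the earlier compounds offered only the comparison of fluoro with methoxy. Compound 4 also gives 4-methylphenyl its first comparison with an otherwise unsubstituted phenyl, a number 0.42 log units lower from compound 2 to compound 4 (beyond the scatter), a modest step that differs in the methyl alone, although compound 2 and compound 3 remain within the scatter of each other, so the methyl compound does not stand clear of every other member.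

No information given here accounts for any of these steps. On these data alone, it remains open whether the flat response at this place would hold for an amine, a nitrile or a longer chain on the same ring, and whether fluoro or methoxy on the ring carbon that carries the methyl in compound 2 would give a step like the one seen with methyl.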